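Compound 3 to compound 4: an all-carbon ring group enters

The source may report more compounds than this note shows. Statements on the series, on what has been measured and on what is new or still open speak of the compounds shown alone.

In an ADME assay on Vero cells (Chlorocebus sabaeus) for cytotoxicity, read by CellTiter-Glo, with a stated time of 72 h (a lower number here means that less compound is tolerated, a higher number that more compound is tolerated), compound 1 `CCNc1n[n+]([O-])c2cc(F)ccc2[n+]1[O-]` gives 4.6 ug/mL and compound 2 `[O-][n+]1nc(NC2CCC2)[n+]([O-])c2ccc(F)cc21` gives 1.6 ug/mL on the shared core. Compound 3 `COCC(C)Nc1n[n+]([O-])c2cc(F)ccc2[n+]1[O-]` gives 6.3 ug/mL and lies within the scatter of compound 1 but clear of compound 2. Compound 4 `[O-][n+]1nc(N[C@@H]2C[C@H]3CC[C@@H]2C3)[n+]([O-])c2ccc(F)cc21` carries a group of 7 heavy atoms (7 carbon; 2 five-membered non-aromatic rings of carbon only) in place of a group of 5 heavy atoms (4 carbon, 1 oxygen; no ring), on a nitrogen on an aromatic ring relative to compound 3. Among the measured compounds only compound 2 has a ring on that nitrogen. Both a 2.9-fold lower number from compound 1 to compound 2 (0.46 log units; beyond the scatter) and a 3.9-fold higher number from compound 2 to compound 3 (0.60 log units; beyond the scatter) lie beyond the scatter, while a 1.4-fold higher number from compound 1 to compound 3 (0.14 log units; within the scatter) stays within it. On this single case a modest drop is expected in this assay for compound 4. The step expected is a 2.9-fold lower number from compound 3 to compound 4 (0.46 log units; beyond the scatter) on this reading. For compound 4 the estimate is 2.2 ug/mL with an expected range from 0.8 ug/mL to 6 ug/mL in this measure.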

Compound 4, half-maximal cytotoxic concentration: < 2.5 ug/mL
Compound 4 ended at the assay's limit; the forecaster's own chance of this, stated with the estimate: 3%; the middle value lies beyond the limit too.
By their numbers in this assay, from the lowest: compound 2; then compounds 1 and 3 (each within the scatter of the next).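

In this assay compound 4 gives < 2.5 ug/mL as a limit of the assay and not a number. The readable steps are an at least 2.5-fold lower number from compound 3 to compound 4 (0.40 log units; beyond the scatter) and an at least 1.8-fold lower number from compound 1 to compound 4 (0.26 log units; that floor lies within the scatter) so a second all-carbon ring group on that nitrogen, after the cyclobutyl of compound 2, stands lower than the 1-(methoxymethyl)ethyl of compound 3. The step from compound 2 cannot be read because of the limit: the limit of < 2.5 ug/mL in this assay, at which 1 of the 4 values shown sits.

Open, on these data alone, is the order of compound 2 and compound 4. Also open, as far as these compounds go, is whether a tetrahydropyranyl ring or a chain carrying an amine on that nitrogen stays level with compound 3.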